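Chain-extended analogue in the TRPV1 displacement series

A few compounds are considered here, and "the series" means these few. Any claim that something is new, unique, unknown or untested is made for them only; others in the source may bear on it.

Measured so far:
compound 1 `CC(C(=O)NCc1ccc(Cl)cc1)c1ccc(NS(C)(=O)=O)c(F)c1` 1060 nM
compound 2 `CC(C(=O)NCc1ccc(C2CC2)cc1)c1ccc(NS(C)(=O)=O)c(F)c1` 411 nM

In an assay on CHO cells for displacement of a labelled ligand from transient receptor potential cation channel subfamily V member 1 (Rattus norvegicus) (a higher number here means a weaker inhibitor, a lower number a stronger inhibitor), compound 2 stands lowest of the two numbers, compound 1 giving the higher one, and the step of a 2.6-fold lower number from compound 1 to compound 2 (0.41 log units; beyond the scatter) shows that change. Compound 3 `CC(C(=O)NCCCc1ccc(Cl)cc1)c1ccc(NS(C)(=O)=O)c(F)c1` carries 2-(4-chlorophenyl)ethyl in place of 4-cyclopropylphenyl on a saturated chain carbon bound to an amide-type nitrogen. For the measured compounds named here, only the step from compound 1 to compound 2 bears on this, and it concerns the chloro-for-cyclopropyl swap alone; no measured pair covers the lengthened chain. Returning to chloro should give back that step, and the longer chain adds uncertainty, so compound 3 is expected at 2000 nM (range 600 nM to 7000 nM), a step of a 4.9-fold higher number from compound 2 to compound 3 (0.69 log units; beyond the scatter).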

Compound 3, inhibition constant: 470 nM
For compound 3 the middle estimate is 4.3-fold (0.63 log units) above the measured one; measured number below the stated range.
By their numbers in this assay, from the lowest: compounds 2 and 3 (each within the scatter of the next); then compound 1.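

In this assay, 2-(4-chlorophenyl)ethyl in place of 4-chlorophenyl on a saturated chain carbon bound to an amide-type nitrogen gives a 2.3-fold lower number from compound 1 to compound 3 (0.35 log units; beyond the scatter) and so shows that lengthening the chain alone, with the chloro kept, moves the number at this position. Set against 4-cyclopropylphenyl at the same place, the same group gives a 1.1-fold higher number from compound 2 to compound 3 (0.06 log units; within the scatter) and so two different changes to compound 1 end at numbers that cannot be told apart. No evidence at hand explains this. On these data alone, whether cyclopropyl on the longer chain would add to the chain's step stays open, as does what a still longer chain or an amine in the chain would give.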